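Acetamido in place of methylsulfonyl: compound 4

A few compounds are considered here, and "the series" means these few. Any claim that something is new, unique, unknown or untested is made for them only; others in the source may bear on it.

Measured compounds:
compound 1 `Cc1cc(Nc2nn(Cc3ccc(S(C)(=O)=O)cc3)c(=O)c3ccccc23)n[nH]1`: 4500 nM
compound 2 `Cc1ccc(-n2nc(Nc3cc[nH]n3)c3ccccc3c2=O)cc1`: "not determined" (no result reported)
compound 3 `Cc1cc(Nc2nn(Cc3csc(C)n3)c(=O)c3ccccc23)n[nH]1`: > 30000 nM

Three compounds share the core of compound 1 and were run in a functional assay on MCF7 cells (Homo sapiens) for cytotoxicity; on this read-out higher numbers stand for weaker inhibition and lower numbers for stronger inhibition. Compound 1 is the only one that gives a single number in this assay; for compound 2 no result is reported. Compound 3 returns only a limit of the assay, (the limit of > 30000 nM in this assay, at which 1 of the 3 values shown sits), so its entry is not a number and sets no order against compound 1. Going by the values given here, no pair of measured compounds differs in one place, so no measured step is available within the set.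

Compound 4 `CC(=O)Nc1ccc(Cn2nc(Nc3cc(C)[nH]n3)c3ccccc3c2=O)cc1` differs from compound 1 by acetamido in place of methylsulfonyl on an aromatic carbon. Among the compounds with values here, with no measured step to lean on, the step of a 1.4-fold higher number from compound 1 to compound 4 (0.16 log units; within the scatter) is expected to be small, at the edge of the scatter, leaning toward weaker inhibition. Compound 4 is accordingly estimated at 6500 nM, with a range from 1500 nM to 25000 nM, the chance of a bare limit being kept in mind.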

Compound 4, half-maximal inhibitory concentration: > 30000 nM
Compound 4: only a limit was reported; the forecaster's own chance of this, stated with the estimate: 20%; middle value at least 4.6-fold (0.66 log units) from the limit.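

In this assay, the aromatic carbon para to a large group now has its first measured step: acetamido in place of methylsulfonyl gives an at least 6.6-fold higher number from compound 1 to compound 4 (0.82 log units; beyond the scatter). The two groups are therefore not interchangeable at this position, and among the compounds shown only compound 1 keeps a single number, 4500 nM. The entry for compound 4 is a limit and not a number, so the step fixes only a minimum size: the limit of > 30000 nM in this assay, at which 2 of the 4 values shown sit.

The compounds shown do not tell whether the reading of compound 1 depends on methylsulfonyl itself or would also hold for other groups at this place, such as a sulfonamide, a nitrile or a carboxylic acid. As far as these compounds go, how far compound 4 lies past its limit also stays open.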